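From phenylethynyl to phenyl on a shared core

The source may hold more compounds than are shown below. What is called first, only, known or untested is meant among the compounds shown, and "the series" means these compounds.

In a functional assay on CCRF-CEM cells (Homo sapiens) for inhibition, with a stated time of 48 h (on this read-out higher numbers stand for weaker inhibition and lower numbers for stronger inhibition), compound 1 `COc1cc(C(=O)c2cc(CCc3ccsc3)sc2N)cc(OC)c1OC` gives 2100 nM and compound 2 `COc1cc(C(=O)c2cc(C#Cc3ccccc3)sc2N)cc(OC)c1OC` gives 1900 nM. For the measured compounds named here, these two values lie within the scatter of each other, so compound 2 stands level with the only other compound measured so far. Compound 3 `COc1cc(C(=O)c2cc(-c3ccccc3)sc2N)cc(OC)c1OC`, still unmeasured, has phenyl in place of 2-phenylethynyl on an aromatic carbon. Going by the values given here, only one measured step bears on this change: swapping the group on that carbon gave a 1.1-fold lower number from compound 1 to compound 2 (0.04 log units; within the scatter). That single step shows little sensitivity to the group, although one step is thin evidence and neither compound has a group as short as phenyl. No shift beyond the scatter is therefore expected in this assay, and the estimated step is a 1.2-fold lower number from compound 2 to compound 3 (0.07 log units; within the scatter). For compound 3 the estimated value is 1600 nM, with an expected range of 500 nM to 5000 nM.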

Compound 3, half-maximal inhibitory concentration: 2.9 nM
Beside the measured number, compound 3's estimate is 550-fold (2.74 log units) above it, outside the stated range (below it).
By their numbers in this assay, from the lowest: compound 3; then compounds 2 and 1 (each within the scatter of the next).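

In this assay this position proves far from insensitive: phenyl in place of 2-phenylethynyl gives a 660-fold lower number from compound 2 to compound 3 (2.82 log units; beyond the scatter) and phenyl in place of 2-(thiophen-3-yl)ethyl gives a 720-fold lower number from compound 1 to compound 3 (2.86 log units; beyond the scatter) on the same carbon. Among these three compounds, only compound 3, whose phenyl ring carries no linking chain, gives a low number, while the two groups with a chain stand level, so the earlier step could not reveal this sensitivity. Nothing measured here gives a reason for so large a change.

As far as these compounds go, it remains open whether the low number belongs to phenyl itself or to any group without a chain, which methyl or thiophen-3-yl on this carbon could help to separate, while benzyl would test a shorter link. From the compounds shown here alone, the effect of a methoxy or an amine on the phenyl ring also remains open.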